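Isopropyl Added to the Cinnamamide of Compound 2

The source may report more compounds than this note shows. Statements on the series, on what has been measured and on what is new or still open speak of the compounds shown alone.

Compound 1, `CC(C)(C)c1ccc(CCC(=O)Nc2ccc3c(c2)OCCO3)cc1`, gives 150 nM.
Compound 2, `O=C(/C=C/c1ccccc1)Nc1ccc2c(c1)OCCO2`, gives > 4000 nM.

Both were tested in a functional assay on CHO cells for inhibition of transient receptor potential cation channel subfamily V member 1 (Homo sapiens); on this read-out higher numbers stand for weaker inhibition and lower numbers for stronger inhibition. Compound 1, a saturated propanamide carrying a tert-butyl group, gives 150 nM. Compound 2 is an unsubstituted cinnamamide on the same core. In this assay compound 2 gives > 4000 nM, which is a limit of the assay and not a number; compound 2 therefore stands at the limit of > 4000 nM in this assay, at which 1 of the 2 values shown sits, and only that much is known about it.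

Compound 3, `CC(C)c1ccc(/C=C/C(=O)Nc2ccc3c(c2)OCCO3)cc1`, has not yet been measured. It differs from compound 2 by isopropyl in place of hydrogen on an aromatic carbon. Among the compounds with values here, no measured pair shows this step, so its size is an expectation only. Because compound 1, which carries a bulky alkyl group, gives 150 nM, compound 3 is expected to be a clearly stronger inhibitor than compound 2, a step of an at least 10-fold lower number from compound 2 to compound 3 (1.00 log units; beyond the scatter) well beyond the scatter. Compound 3 is estimated at 400 nM, within 100 nM to 3000 nM.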

Compound 3, half-maximal inhibitory concentration: 55 nM
Estimate against measurement, compound 3: 7.3-fold (0.86 log units) above; the measured number lies below the stated range.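

In this assay, within the data shown here, isopropyl in place of hydrogen on an aromatic carbon, para to a large group, gives an at least 72-fold lower number from compound 2 to compound 3 (1.86 log units; beyond the scatter), the first step that can be read at this position, and it is large. Its true size remains unfixed, as compound 2 is held only by a limit of the assay and not by a number: the limit of > 4000 nM in this assay, at which 1 of the 3 values shown sits. The result gives the size of this change and no cause for it.

Going by these compounds, how a methyl, a trifluoromethyl or a methoxy at this position would compare with isopropyl stays open. On these data alone, compound 1 differs from compound 3 in more than one place, so the part played by the double bond of the cinnamamide also remains open.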